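Swapping an Aryl Ring for an Ester on the Triazole-Bearing Sugar

A few compounds are considered here, and "the series" means these few. Any claim that something is new, unique, unknown or untested is made for them only; others in the source may bear on it.

Compound 3 `CCS[C@@H]1[C@H](SCC)[C@@H](Cn2cc(-c3ccc(C)cc3)nn2)O[C@H]1n1cc(C)c(=O)[nH]c1=O` gives 21600 nM in a functional assay on HepG2 cells (Homo sapiens) for cytotoxicity, read by MTT assay, with a stated time of 72 h; a higher number here means that more compound is needed for the effect, a lower number that less compound is needed. Among the two numbers available it is the lowest, but its nearest neighbour, compound 2 `CCS[C@@H]1[C@H](SCC)[C@@H](Cn2cc(-c3ccccc3C(F)(F)F)nn2)O[C@H]1n1cc(C)c(=O)[nH]c1=O`, gives 22100 nM in this assay, and the step of a 1.0-fold lower number from compound 2 to compound 3 (0.01 log units; within the scatter) lies within the scatter, so the two cannot be ordered. In this assay compound 1 `CCOC(=O)c1cn(C[C@H]2O[C@@H](n3ccc(=O)[nH]c3=O)[C@H](SCC)[C@@H]2SCC)nn1` reaches only a limit, >= 100000 nM, and no number is known for it.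

Compound 4 `CCOC(=O)c1cn(C[C@H]2O[C@@H](n3cc(C)c(=O)[nH]c3=O)[C@H](SCC)[C@@H]2SCC)nn1` has not yet been measured; it differs from compound 3 by ethoxycarbonyl in place of 4-methylphenyl on an aromatic carbon. Among the compounds with values here, the only measured step, from compound 2 to compound 3, exchanged one aromatic ring for another and stayed within the scatter, so it offers little guidance for replacing the ring with an ester. Compound 1 carries the same ethoxycarbonyl and sits at the limit of >= 100000 nM in this assay, at which 1 of the 3 values shown sits. Compound 4 is therefore expected to give a higher number, estimated at 80000 nM, with a range from 25000 nM to 200000 nM. That estimate corresponds to an expected step of a 3.7-fold higher number from compound 3 to compound 4 (0.57 log units; beyond the scatter).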

Compound 4, half-maximal effective concentration: >= 100000 nM
Compound 4: no number, only a limit; the forecaster's own chance of this, stated with the estimate: 50%; middle value at least 1.2-fold (0.09 log units) away from the limit.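

Within the data shown here, until now, the only change at this aromatic carbon had exchanged one aromatic ring for another, with no readable effect; replacing the ring with ethoxycarbonyl is the first change here to go beyond the scatter in this assay, giving an at least 4.6-fold higher number from compound 3 to compound 4 (0.66 log units; beyond the scatter) and an at least 4.5-fold higher number from compound 2 to compound 4 (0.65 log units; beyond the scatter). The size of the ortho-free or substituted aryl group therefore mattered less than having an aromatic ring at all, at least among these compounds.

Compound 4 joins compound 1 at a limit rather than a number, so the step between them cannot be read: the limit of >= 100000 nM in this assay, at which 2 of the 4 values shown sit.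

As far as these compounds go, how far past that limit the two ethoxycarbonyl compounds lie remains open. Also open, from the compounds shown here alone, is whether the loss of cytotoxicity follows from the ester itself or simply from losing the aromatic ring, which a carboxylic acid, an amide or a plain butyl chain at this carbon could help separate.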